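A few compounds are considered here, and "the series" means these few. Any claim that something is new, unique, unknown or untested is made for them only; others in the source may bear on it.

Compound 1 `Fc1cccc(Nc2nccc(-c3ccccn3)n2)c1` gives 1000 nM in a functional assay for inhibition, with Homo sapiens as the target; a higher number here means a weaker inhibitor, a lower number a stronger inhibitor. Among the measured compounds shown here, compound 2 `Cc1cccc(Nc2nccc(-c3ccccn3)n2)c1` gives 700 nM in this assay, and the one measured step, a 1.4-fold lower number from compound 1 to compound 2 (0.15 log units; within the scatter), is small; the two numbers differ only within the scatter, so neither compound stands apart from the other. Compound 3 `Cc1cccc(Nc2nccc(-c3ccco3)n2)c1` differs from compound 2 by furan-2-yl in place of pyridin-2-yl on an aromatic carbon. For the measured compounds named here, no measured step covers this part of the shared core, as the single known step concerns a different position, so nothing measured here predicts the outcome. Compound 3 is estimated at 1500 nM, between 400 nM and 6000 nM, which would mean an expected 2.1-fold higher number from compound 2 to compound 3 (0.33 log units; beyond the scatter).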

Compound 3, half-maximal inhibitory concentration: 2100 nM
Compound 3: the middle estimate sits 1.4-fold (0.15 log units) below what was measured; measured number inside the range.
By their numbers in this assay, from the lowest: compounds 2 and 1 (each within the scatter of the next); then compound 3.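

Among the compounds shown here, with a 3.0-fold higher number from compound 2 to compound 3 (0.48 log units; beyond the scatter) in this assay, this position on the shared core is the first place here where a change moves the number beyond the scatter. Pyridin-2-yl and furan-2-yl each count one hetero atom and one hydrogen-bond acceptor, yet the swap changes both ring size and the hetero atom, and the data cannot separate these two differences. Nothing available explains the shift. Still open, as far as these compounds go, is how a plain phenyl ring or a thiophene would compare at this carbon. Also open, from the compounds shown here alone, is whether fluoro in place of methyl would stay within the scatter alongside furan-2-yl.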